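This account rests on a few compounds, and the source may have more. Where it says the series, first, only, none or still open, it means among the compounds named here.

The measured compounds and their values in this assay:

compound 1, `Fc1ccc2nc(-c3cn[nH]c3)n(C3CC3)c2c1`, 782 nM
compound 2, `Fc1ccc2nc(-c3cnccn3)n(C3CC3)c2c1`, 541 nM
compound 3, `Fc1cc2nc(-c3cncnc3)n(C3CC3)c2cc1F`, 22 nM

In an assay on cells for inhibition of cytochrome P450 11B2, mitochondrial (Homo sapiens), read by HPLC, with a stated time of 90 min (on this read-out higher numbers stand for weaker inhibition and lower numbers for stronger inhibition), compound 3 stands at the lowest number of the three, and its distance from both other compounds lies beyond the scatter. Compound 2 gives 541 nM, and compound 1 gives 782 nM. Within the data shown here, the one step that can be followed between compounds differing in a single place is a 1.4-fold lower number from compound 1 to compound 2 (0.16 log units; within the scatter), which exchanged one ring for another and stayed within the scatter.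

Compound 4, `N#Cc1ncncc1-c1nc2cc(F)c(F)cc2n1C1CC1`, is reached from compound 3 by cyano in place of hydrogen on an aromatic carbon. Among the measured compounds shown here, none of the measured steps bears directly on this change: the only step available swaps one aromatic ring for another, whereas here a cyano group is added to a ring that is otherwise kept. The data therefore give no reason to expect a move beyond the scatter in either direction.

Compound 4 is expected to give about 25 nM in this assay, in a range from 8 nM to 80 nM. This corresponds to an estimated step of a 1.1-fold higher number from compound 3 to compound 4 (0.06 log units; within the scatter), which is expected to remain within the scatter.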

Compound 4, half-maximal inhibitory concentration: 13 nM
Beside the measured number, compound 4's estimate is 1.9-fold (0.28 log units) above it; low and high end bracket the measured number.
By their numbers in this assay, from the lowest: compounds 4 and 3 (each within the scatter of the next); then compounds 2 and 1 (each within the scatter of the next).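

In this assay, cyano in place of hydrogen on the aromatic carbon next to the ring nitrogen is a 1.7-fold lower number from compound 3 to compound 4 (0.23 log units; within the scatter), so this position of the six-membered aromatic ring with 2 nitrogen takes cyano and its 2 heavy atoms without a move beyond the scatter. The earlier compounds shown here offered only an exchange of one ring for another, whereas this pair keeps the ring and adds a group to it, and the number stays in the same low range: compound 3 gives 22 nM and compound 4 gives 13 nM in this assay. Nothing at hand offers an account of why this change leaves the number within the scatter.

The compounds shown leave open whether an amine, a carboxylic acid or a methyl group on this same carbon would stay within the scatter of compound 3 or move beyond it. They also leave open whether cyano would give a similarly small step on the pyrazin-2-yl ring of compound 2, since this single pair speaks for one ring only.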